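Working notes on a methoxy step in a growth-inhibition series

The source may hold more compounds than are shown below. What is called first, only, known or untested is meant among the compounds shown, and "the series" means these compounds.

Measured in a functional assay on A2780 cells (Homo sapiens) for inhibition, read by sulforhodamine B assay; on this read-out higher numbers stand for weaker inhibition of growth and lower numbers for stronger inhibition of growth:
compound 1 `c1ccc(-c2ccc(-c3ccc(-c4nc5ccccc5[nH]4)cc3)cc2)cc1`: 32100 nM
compound 2 `COc1ccc(-c2ccc(-c3ccc(-c4nc5ccccc5[nH]4)cc3)cc2)cc1`: 100000 nM
compound 3 `COc1ccc(-c2ccc(-c3ccc(-c4nc5c(O)cccc5[nH]4)cc3)cc2)cc1OC`: 2710 nM

Compounds 1 and 2 differ by methoxy in place of hydrogen on an aromatic carbon, and that step in this assay is a 3.1-fold higher number from compound 1 to compound 2 (0.49 log units; beyond the scatter). Compound 3 gives the lowest number of the three; how its core differs from the core of compound 1 is not broken down here.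

Compound 4 `COc1cc(-c2ccc(-c3ccc(-c4nc5c(O)cccc5[nH]4)cc3)cc2)cc(OC)c1OC` differs from compound 3 by methoxy in place of hydrogen on an aromatic carbon. This is the same kind of change as from compound 1 to compound 2, not the same: there the entering methoxy was para to a large group, here it is ortho to a methoxy group, meta to a large group and meta to a methoxy group.

The expectation rests on compound 1 and compound 2, where the step was a 3.1-fold higher number from compound 1 to compound 2 (0.49 log units; beyond the scatter); a step of similar direction and size is expected from compound 3 to compound 4, namely a 2.4-fold higher number from compound 3 to compound 4 (0.38 log units; beyond the scatter). The surroundings of the new group differ, so the estimate is held wide. In this assay compound 4 is expected to give 6500 nM, with a range from 1800 nM to 25000 nM.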

Compound 4, concentration for 50% growth inhibition: 170 nM
Compound 4: the middle estimate sits 38-fold (1.58 log units) above what was measured; the whole stated range lies above it.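

In this assay, methoxy in place of hydrogen on an aromatic carbon gives a 16-fold lower number from compound 3 to compound 4 (1.20 log units; beyond the scatter), so in this series the change does not keep its direction from one core to another: the same change on two cores in this assay, a 3.1-fold higher number (0.49 log units; beyond the scatter) from compound 1 to compound 2 and a 16-fold lower number (1.20 log units; beyond the scatter) from compound 3 to compound 4, 50-fold (1.70 log units) apart, beyond the scatter of two such steps.

The result shows that the step measured on the core of compound 1 is no safe guide to the same change on the core of compound 3. It does not show what sets the two steps apart, since the cores differ and so do the surroundings of the entering methoxy, which is para to a large group in compound 2 but ortho to a methoxy group, meta to a large group and meta to a methoxy group in compound 4.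

The compounds shown leave open whether methoxy at this same place on the core of compound 1 would follow the step seen on the core of compound 3. They also leave open whether an ethoxy group or an amine at that place would go the way of methoxy.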